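This account rests on a few compounds, and the source may have more. Where it says the series, first, only, none or still open, it means among the compounds named here.

Measured in a functional assay on MC-38 cells (Mus musculus) for antiproliferative activity, read by CCK-8 assay, with a stated time of 48 h; on this read-out lower numbers stand for stronger inhibition and higher numbers for weaker inhibition:
- compound 1 `COc1ccc(/C=C\c2cc(OC)c(OC)c(OC)c2)cc1OCc1ccc(C=O)cc1`: 900 nM
- compound 2 `COc1ccc(/C=C\c2cc(OC)c(OC)c(OC)c2)cc1OCc1ccc(CN2CCCCC2C(=O)O)cc1`: 5400 nM
- compound 3 `COc1ccc(/C=C\c2cc(OC)c(OC)c(OC)c2)cc1OCc1ccc(CNCCO)cc1`: 1200 nM

The data show a 1.3-fold higher number from compound 1 to compound 3 (0.12 log units; within the scatter), so these two compounds cannot be told apart. Compound 2 stands clearly apart, with a 4.5-fold lower number from compound 2 to compound 3 (0.65 log units; beyond the scatter).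

The next compound, compound 4 `COc1ccc(/C=C\c2cc(OC)c(OC)c(OC)c2)cc1OCc1ccc(CN2CC[C@H](C(=O)O)C2)cc1`, keeps the shared core and changes one group, with 3-carboxypyrrolidin-1-yl in place of (2-hydroxyethyl)amino on a saturated chain carbon bound to an aromatic carbon.

Among the compounds with values here, no measured compound carries this exact group. The nearest guide is compound 2, whose 2-carboxypiperidin-1-yl group also holds a carboxy substituent. Within the data shown here, two measured steps bear on the change. One is a 6.0-fold higher number from compound 1 to compound 2 (0.78 log units; beyond the scatter), and the other is the modest 4.5-fold lower number from compound 2 to compound 3 (0.65 log units; beyond the scatter) already seen. Read backwards, the second suggests that exchanging (2-hydroxyethyl)amino for a carboxy-bearing group moves the number upward, towards weaker inhibition. This is a single comparison, and the two groups differ in ring and in carboxy placement, so the full size of that step may not carry over.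

A modest rise is therefore expected, estimated as a 2.9-fold higher number from compound 3 to compound 4 (0.46 log units; beyond the scatter). The estimate for compound 4 is 3500 nM, with an expected range from 1300 nM to 9000 nM.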

Compound 4, half-maximal inhibitory concentration: > 10000 nM
Compound 4 was reported as a limit; the forecaster's own chance of this, stated with the estimate: 5%; middle value at least 2.8-fold (0.45 log units) from the limit.
By their numbers in this assay, from the lowest: compounds 1 and 3 (each within the scatter of the next); then compound 2. At a limit, above all of these: compound 4.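

In this assay compound 4 gives no exact number, only a limit: the limit of > 10000 nM in this assay, at which 1 of the 4 values shown sits. Even so, replacing (2-hydroxyethyl)amino with 3-carboxypyrrolidin-1-yl on a saturated chain carbon bound to an aromatic carbon clearly weakens inhibition, with an at least 8.3-fold higher number from compound 3 to compound 4 (0.92 log units; beyond the scatter), and the comparison with the formyl compound gives an at least 11-fold higher number from compound 1 to compound 4 (1.04 log units; beyond the scatter). The earlier link between a carboxy-bearing ring and weaker inhibition rested on compound 2 alone; compound 4 now shows the same direction with a different ring and carboxy placement, and no compound shown goes against it, although an at least 1.8-fold higher number from compound 2 to compound 4 (0.26 log units; that floor lies within the scatter), so compound 4 cannot be separated from compound 2.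

The compounds shown leave open whether the weakening follows the carboxylic acid or the ring, since a plain pyrrolidin-1-yl group, or a methyl ester in place of the acid, would help to separate the two. They also leave open what the opposite configuration at the defined stereocentre of the 3-carboxypyrrolidin-1-yl group would give.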